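This account rests on a few compounds, and the source may have more. Where it says the series, first, only, none or still open, it means among the compounds named here.

Measured compounds:
- compound 1, `Cc1c(-c2cc(Cl)cc(Cl)c2)c(C(=O)O)nn1-c1nc(-c2cccnc2)c(SC(C)C)s1`: in a functional assay on BJAB cells (Homo sapiens) for antiproliferative activity, with a stated time of 4 days (a lower number here means that less compound is needed, a higher number that more compound is needed for the effect), it is reported as "not active" (no number reported)
- compound 2, `CCSc1sc(-n2nc(C)c(Cc3ccccc3[N+](=O)[O-])c2C(=O)O)nc1-c1ccc(Cl)c(Cl)c1`: in this assay compound 2 gives 59000 nM
- compound 3, `COc1ccc(-c2c(C)nn(-c3nc(-c4ccc(Cl)c(Cl)c4)c(SC(C)C)s3)c2C(=O)O)cc1`: in this assay compound 3 gives 2100 nM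

All three share one core, which differs only in the group carried on one aromatic carbon of the five-membered ring. Of the two compounds that received a number in this assay, compound 3 has the lower one, and its gap to compound 2 lies beyond the usual scatter of repeated measurements; compound 1 gave no number at all.

The next compound, compound 4, `Cc1nn(-c2nc(-c3ccc(Cl)c(Cl)c3)c(SC(C)C)s2)c(C(=O)O)c1-c1cncc(C#N)c1`, starts from compound 3 and carries one change: 5-cyanopyridin-3-yl in place of 4-methoxyphenyl on an aromatic carbon. Going by the values given here, no pair among the measured compounds tests this exchange, so the direction of the step cannot be read off any known step. A moderate loss is expected, somewhat beyond the scatter, rather than a gain.

In this assay compound 4 is therefore estimated at 5000 nM, with a range from 1200 nM to 25000 nM. This corresponds to an expected step of a 2.4-fold higher number from compound 3 to compound 4 (0.38 log units; beyond the scatter).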

Compound 4, half-maximal effective concentration: 20000 nM
For compound 4 the middle estimate is 4.0-fold (0.60 log units) below the measured one; low and high end bracket the measured number.
By their numbers in this assay, from the lowest: compound 3; then compound 4; then compound 2.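

In this assay, going by these compounds alone, replacing 4-methoxyphenyl with 5-cyanopyridin-3-yl gives a 9.5-fold higher number from compound 3 to compound 4 (0.98 log units; beyond the scatter), the first change at a single place that can be read. The two groups have the same count of heavy atoms and each contains one six-membered aromatic ring, so the heavy-atom count alone does not set the number at this position, on the aromatic carbon that lies next to the ring atoms bearing the carboxy and methyl groups. No measurement here explains why the number rises, so the step records an outcome and not a cause.

The exchange alters several features at once: a ring nitrogen and a nitrile enter while the methoxy group leaves, and the compounds shown cannot divide the step among them. A plain phenyl group or a cyanophenyl group at this position would help to separate these contributions, and a single step in one assay leaves open whether the same trend would hold for other groups here.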